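A few compounds are considered here, and "the series" means these few. Any claim that something is new, unique, unknown or untested is made for them only; others in the source may bear on it.

Series notes. Compound 1 `COc1ccccc1/C=C/S(=O)(=O)Cc1ccc(OC)c([N+](=O)[O-])c1` carries a nitro group on its core; in a functional assay on DU-145 cells (Homo sapiens) for cytotoxicity, read by trypan blue exclusion, with a stated time of 96 h (on this read-out higher numbers stand for weaker inhibition and lower numbers for stronger inhibition), compound 1 gives 20000 nM. Compound 2 `COc1ccc(CS(=O)(=O)/C=C/c2ccccc2OC)cc1N` is the amino counterpart, the change being (amino in place of nitro on an aromatic carbon). In this assay, within the data shown here, compound 2 gives 7500 nM, and the step of a 2.7-fold lower number from compound 1 to compound 2 (0.43 log units; beyond the scatter) is the only measured instance of this change so far. Compound 3 `COc1cc(OC)c(/C=C/[S+]([O-])Cc2ccc(OC)c([N+](=O)[O-])c2)c(OC)c1` is built on a different core; the difference between the two cores is not broken down here. In this assay compound 3 gives 15000 nM, which against compound 1 and against compound 2 lies within the scatter, so no order among those three is claimed. Compound 4 `COc1cc(OC)c(/C=C/[S+]([O-])Cc2ccc(OC)c(N)c2)c(OC)c1` has not been measured. It differs from compound 3 by amino in place of nitro on an aromatic carbon, the same change as that from compound 1 to compound 2, with the same surroundings described at the place. Because a 2.7-fold lower number from compound 1 to compound 2 (0.43 log units; beyond the scatter) was the size of this change on the other core, a step of similar size is expected for compound 4: a 2.7-fold lower number from compound 3 to compound 4 (0.44 log units; beyond the scatter). Compound 4 is therefore estimated at 5500 nM in this assay. Given a single prior instance, the expected range for compound 4 runs from 2500 nM to 12000 nM.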

Compound 4, half-maximal inhibitory concentration: 40 nM
For compound 4 the middle estimate is 140-fold (2.14 log units) above the measured one; measured number outside the range, below it.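

Amino in place of nitro on an aromatic carbon gives a 380-fold lower number from compound 3 to compound 4 (2.57 log units; beyond the scatter) in this assay, and the size of the change did not carry over from one core to the other: the same change on two cores in this assay, a 2.7-fold lower number (0.43 log units; beyond the scatter) from compound 1 to compound 2 and a 380-fold lower number (2.57 log units; beyond the scatter) from compound 3 to compound 4, 140-fold (2.15 log units) apart, beyond the scatter of two such steps. Both instances run in the same direction, towards a lower number, so in this series the direction is shared, while a step measured on one core gave no reliable measure of its size on the other. The two pairs do not show which feature of the cores goes with the gap, and two instances support no general rule for other cores.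

The compounds shown leave open whether the large step belongs to the amino group specifically or would also appear with another group at that place on the core of compound 3, such as a hydroxyl group, a methylamino group or an acetamide. Also open, going by these compounds, is whether a core holding only part of the difference between the two cores would give a step of intermediate size.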